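This account rests on a few compounds, and the source may have more. Where it says the series, first, only, none or still open, it means among the compounds named here.

Working notes on the series. Two compounds carry a number in a functional assay on muscle tissue for agonist activity at histamine H2 receptor (Cavia porcellus); a higher number here means a larger maximal response, a lower number a smaller maximal response. Compound 1, `COc1ccc(C(CC/N=C(\N)NCCCc2c[nH]cn2)c2ccccn2)cc1`, gives 0.5 in this assay. Compound 2, `N=C(NCCCc1c[nH]cn1)NCCC(c1ccc(Cl)cc1)c1ccccn1`, gives 0.8 in this assay, the higher of the two numbers, and the gap to compound 1 lies beyond the usual scatter of repeated measurements; what the two compounds show is that the group on the saturated chain carbon matters for the largest response reached.

Compound 3 is `N=C(NCCCc1c[nH]cn1)NCCC(c1cccc(F)c1)c1ccccn1`. Its relation to compound 2 is 3-fluorophenyl in place of 4-chlorophenyl on a saturated chain carbon bound to an aromatic carbon and a saturated chain carbon. Among the compounds with values here, no pair of measured compounds differs in this one place, so there is no measured step to lean on; the only comparison available is the gap between compound 1 and compound 2, which both change the six-membered aromatic ring of carbon only in a different way.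

Compound 3 is expected to stay close to compound 2 in this assay, with the step a number 0.10 lower from compound 2 to compound 3 (within the scatter) estimated as small and downward, at most near the edge of the scatter. The estimate for compound 3 in this assay is 0.7, with a range from 0.5 to 0.9.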

Compound 3, intrinsic activity: the largest response reached, as a fraction of the reference agonist's: 0.5
The estimate for compound 3 lay 0.20 above the measured number; low and high end bracket the measured number.
By their numbers in this assay, from the lowest: compounds 1 and 3 (each within the scatter of the next); then compound 2.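

In this assay, within the data shown here, the replacement of 4-chlorophenyl by 3-fluorophenyl on this saturated chain carbon gives a number 0.30 lower from compound 2 to compound 3 (beyond the scatter) and is the only measured single change at this position so far. Both groups have the same count of heavy atoms, one six-membered aromatic ring of carbon only, no hydrogen-bond donors or acceptors and no net charge, so those matching counts do not keep the largest response the same here. Compound 1 gives 0.5 in this assay and compound 3 gives 0.5 in the same assay, so compound 2 stands alone among these three compounds, and its 4-chlorophenyl group is the one feature that separates it from compound 3.

Because the halogen and its ring position change together, the step cannot be assigned to either one, and 3-chlorophenyl or 4-fluorophenyl at this carbon would be needed to separate the two. No measurement shown gives a reason for the step.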